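Dipropylamino in Place of Dimethylpiperidinyl: Solubility Outlook

A few compounds are considered here, and "the series" means these few. Any claim that something is new, unique, unknown or untested is made for them only; others in the source may bear on it.

Compound 1 `Cc1ccc2c(c1)[n+]([O-])c(NCCN(C)C)n[n+]2[O-]`: in a physicochemical assay for solubility, in the presence of a further agent that is not named here (on this read-out lower numbers stand for lower solubility and higher numbers for higher solubility), compound 1 gives > 51000000 nM, which is a limit of the assay.
Compound 2 `Cc1ccc2c(c1)[n+]([O-])c(NCCN1C(C)CCCC1C)n[n+]2[O-]`: in this assay compound 2 gives 48000000 nM.

Compound 2 holds the only number shown in this assay; the other value is a limit (the limit of > 51000000 nM in this assay, at which 1 of the 2 values shown sits). The step of an at least 1.0-fold lower number from compound 1 to compound 2 (0.02 log units; that floor lies within the scatter) therefore cannot be sized beyond its floor.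

Compound 3 `CCCN(CCC)CCNc1n[n+]([O-])c2ccc(C)cc2[n+]1[O-]` differs from compound 2 in one place: dipropylamino in place of 2,6-dimethylpiperidin-1-yl on a saturated chain carbon, two bonds along the chain from a nitrogen on an aromatic ring. Within the data shown here, the one measured step that bears on it is the exchange at the same place, an at least 1.0-fold lower number from compound 1 to compound 2 (0.02 log units; that floor lies within the scatter), which lies within the scatter. On that ground no step beyond the scatter is expected in this assay from compound 2 to compound 3, and the estimated step is a 1.1-fold lower number from compound 2 to compound 3 (0.03 log units; within the scatter). Compound 3 is accordingly estimated at 45000000 nM, with a range from 20000000 nM to 70000000 nM, and a fair chance that the assay reports only its limit.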

Compound 3, solubility: 38000000 nM
The estimate for compound 3 lay 1.2-fold (0.07 log units) above the measured number; the range from low to high includes it.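

The exchange of the ring in 2,6-dimethylpiperidin-1-yl for the open chains of dipropylamino gives a 1.3-fold lower number from compound 2 to compound 3 (0.10 log units; within the scatter). Among these compounds, this is the first step at this place in this assay that runs between two numbers, and it shows that, for this pair, giving up the ring on a saturated chain carbon, two bonds along the chain from a nitrogen on an aromatic ring, does not carry the read-out beyond the scatter. Set against the dimethylamino group, the same position gives an at least 1.3-fold lower number from compound 1 to compound 3 (0.12 log units; that floor lies within the scatter), and compound 1 stands at a limit of the assay, so because of that limit this second step cannot be sized beyond its floor: the limit of > 51000000 nM in this assay, at which 1 of the 3 values shown sits.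

From the compounds shown here alone, whether dimethylamino truly differs from 2,6-dimethylpiperidin-1-yl or dipropylamino remains open, as compound 1 offers only a limit. Going by these compounds, it also remains open whether a group of another kind at this place, such as a morpholine ring, a primary amine or a carboxylic acid, would give a step beyond the scatter in this assay.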